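A few compounds are considered here, and "the series" means these few. Any claim that something is new, unique, unknown or untested is made for them only; others in the source may bear on it.

Measured compounds:
- Compound 1, `COc1cc(NC(=O)Nc2cc(Nc3cccc(C(C)(C)C)c3)ncn2)cc(OC)c1`: 40%
- Compound 2, `CC(C)(C)c1ccc(Nc2cc(NC(=O)Nc3c(Cl)cccc3Cl)ncn2)cc1`: 40%
- Compound 3, `COc1ccc(C(F)(F)F)cc1Nc1cc(NC(=O)Nc2c(Cl)cccc2Cl)ncn1`: 60.1%

All three were tested in a functional assay on NCI-H226 cells (Homo sapiens) for inhibition, read by MTT assay, with a stated time of 48 h, tested at 10 uM; on this read-out higher numbers stand for more inhibition at the one concentration tested (going by the name of the read-out) and lower numbers for less inhibition. On these numbers compound 1 stands level with compound 2 at the digits shown, and together they are the lowest of the three. Compound 3 lies a step higher than compound 1, and that gap is beyond the usual scatter; since compound 3 differs from compound 1 in more than one place, the two values alone cannot say which change carries it.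

The step now followed leads to compound 4, `COc1cc(NC(=O)Nc2cc(Nc3ccc(Br)cc3OC)ncn2)cc(OC)c1`, which is yet to be measured. Compared with compound 1 it carries 4-bromo-2-methoxyphenyl in place of 3-(tert-butyl)phenyl on a nitrogen on an aromatic ring. Going by the values given here, no measured pair in this set differs in only that one place, so there is no direct reference for how large a step to expect in this assay. The expectation here is a small rise, with the outcome from compound 1 to compound 4 estimated at a number 6 percentage points higher from compound 1 to compound 4 (within the scatter), which stays inside the scatter. Compound 4 is therefore expected to give about 46%, within a range from 20% to 70%.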

Compound 4, a percentage reported as inhibition, at one concentration (the size of the read-out at that concentration, not a potency): 25.7%
The estimate for compound 4 lay 20.3 percentage points above the measured number; the measured number falls inside the stated range.
By their numbers in this assay, from the lowest: compound 4; then compounds 1 and 2 (each within the scatter of the next); then compound 3.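

In this assay, the group on the nitrogen on an aromatic ring proves able to shift the result: putting 4-bromo-2-methoxyphenyl in place of 3-(tert-butyl)phenyl gives a number 14.3 percentage points lower from compound 1 to compound 4 (beyond the scatter). Going by these compounds alone, this is the first comparison in the set that differs in one place only, so this drop in inhibition can be tied to this change of group, with the rest of compound 1 left as it is. Nothing measured here explains the drop.

On these data alone, the step removes the tert-butyl group and adds a bromine and a methoxy group all at once, so it remains open which of these changes matters and whether any of them would matter alone. Also open, as far as these compounds go, is how this position would respond to a quite different group, such as a simple amine or a carboxylic acid on the phenyl ring.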